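Cytotoxicity notes on a shared-core series, compound 4 pending

The source may report more compounds than this note shows. Statements on the series, on what has been measured and on what is new or still open speak of the compounds shown alone.

The series keeps one core and varies the group on an amine nitrogen of the side chain. Compound 1 `Cc1c(Cc2ccccc2)c(=O)oc2cc(OCC(O)CNc3ccccc3)ccc12` carries phenyl there, compound 2 `Cc1c(Cc2ccccc2)c(=O)oc2cc(OCC(O)CNc3cc([N+](=O)[O-])ccc3O)ccc12` carries 2-hydroxy-5-nitrophenyl, and compound 3 `Cc1c(Cc2ccccc2)c(=O)oc2cc(OCC(O)CNc3ccc(Br)cc3)ccc12` carries 4-bromophenyl. In an ADME assay on A549 cells (Homo sapiens) for cytotoxicity, read by CellTiter-Glo (a higher number here means that more compound is tolerated, a lower number that less compound is tolerated), compound 1 gives > 100000 nM, which is a limit of the assay and not a number. In this assay compound 2 gives > 100000 nM, again a limit. In this assay compound 3 gives > 100000 nM, a limit as well. Compound 2 therefore stands at the same limit as the two other compounds shown; the only evidence on the measured steps is the limit of > 100000 nM in this assay, at which 3 of the 3 values shown sit. The steps a step that the two limits leave unreadable from compound 1 to compound 2, a step that the two limits leave unreadable from compound 1 to compound 3 and a step that the two limits leave unreadable from compound 2 to compound 3 accordingly have no readable size.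

Compound 4 `Cc1c(Cc2ccccc2)c(=O)oc2cc(OCC(O)CNCc3cccs3)ccc12` is not yet measured. It differs from compound 2 as (thiophen-2-yl)methyl in place of 2-hydroxy-5-nitrophenyl on an amine nitrogen. For the measured compounds named here, no measured step touches a (thiophen-2-yl)methyl group, and every measured step is unreadable, so no size can be carried over; the three measured compounds show only that three different groups on that amine nitrogen all leave the compound tolerated up to the limit. The step of a number no higher from compound 2 to compound 4 (the limit leaves the size open) is expected to stay within the scatter. Compound 4 is therefore estimated at 100000 nM, with a range from 40000 nM to 300000 nM in this assay.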

Compound 4, half-maximal cytotoxic concentration: 87300 nM
Compound 4: middle estimate off by 1.1-fold (0.06 log units), on the high side, within the range that was stated.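

Compound 4 is the first compound shown in this assay to give a number and not a limit, so this position on the amine nitrogen now has one measured value, carried by (thiophen-2-yl)methyl, the only group shown with a five-membered aromatic ring and with sulfur. Against the three other groups, the readings are an at least 1.1-fold lower number from compound 2 to compound 4 (0.05 log units; that floor lies within the scatter), an at least 1.1-fold lower number from compound 3 to compound 4 (0.05 log units; that floor lies within the scatter) and an at least 1.1-fold lower number from compound 1 to compound 4 (0.05 log units; that floor lies within the scatter); each is only a floor, so the true size of each step stays open and none shows that this change has a real effect on tolerance. The steps among compound 1, compound 2 and compound 3 still cannot be read, and most of the series still rests on a single limit: the limit of > 100000 nM in this assay, at which 3 of the 4 values shown sit.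

Still open, on these data alone, is whether the value of compound 4 goes with the thiophene ring or with the methyl link to the nitrogen, a question that a benzyl or a thiophen-2-yl group at the same place would separate. Also open, as far as these compounds go, is how a longer chain such as 2-(thiophen-2-yl)ethyl, or a carboxylic acid on the aromatic ring, would read in this assay.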